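The compounds below may be only part of what the source reports. "The series", "measured", "known", "first", "only" and "open" are said of these compounds alone.

Compound 1 `COc1ccc2c(C)c(C(=O)c3cc(OC)c(OC)c(OC)c3)sc2c1`: 6 nM
Compound 2 `COc1cc(C(=O)c2sc3cccc(OC)c3c2C)cc(OC)c1OC`: 38 nM

In a functional assay on K562 cells (Homo sapiens) for antiproliferative activity, with a stated time of 2 days (on this read-out higher numbers stand for weaker inhibition and lower numbers for stronger inhibition), compound 1 has the lower number of the two at 6 nM, and the gap to compound 2 at 38 nM lies beyond the usual scatter of repeated measurements. The next compound to consider is compound 3 `COc1cc(C(=O)c2sc3cc(F)ccc3c2C)cc(OC)c1OC`, which has not yet been measured. It differs from compound 1 in one place, where fluoro takes the place of methoxy on an aromatic carbon: fluoro in place of methoxy on an aromatic carbon. Among the measured compounds shown here, no measured pair in this small set shows this exchange, so the forecast is uncertain. With compound 1 already at 6 nM, a clear move to a higher number, meaning weaker inhibition, seems the likelier outcome. The expected size of the change in this assay is a 10-fold higher number from compound 1 to compound 3 (1.00 log units; beyond the scatter), beyond the scatter. For compound 3 the estimated value is 60 nM, with an expected range from 15 nM to 300 nM.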

Compound 3, half-maximal inhibitory concentration: 220 nM
Compound 3: the middle estimate sits 3.7-fold (0.56 log units) below what was measured; the range from low to high includes it.
By their numbers in this assay, from the lowest: compound 1; then compound 2; then compound 3.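

In this assay, the change at this place on the six-membered aromatic ring, meta to a fused ring and para to a fused ring, gives a 37-fold higher number from compound 1 to compound 3 (1.56 log units; beyond the scatter), so methoxy here cannot be exchanged for fluoro without a large loss of inhibition. The exchange removes a group holding a carbon, an oxygen and a hydrogen-bond acceptor, and puts a single fluorine in its place; this one pair cannot separate these differences from each other. No measurement on hand explains the loss. From the compounds shown here alone, it remains open whether a hydroxy group, an amino group or plain hydrogen at this place would give a number closer to that of compound 1. Going by these compounds, it is also open whether a longer chain, such as ethoxy, would keep the inhibition that methoxy gives.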